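Chloro to methoxy exchange in a small series

The compounds below may be only part of what the source reports. "The series", "measured", "known", "first", "only" and "open" are said of these compounds alone.

The three measured compounds have all been read in an assay on isolated protein for inhibition of beta-glucuronidase (Bos taurus), read by spectrophotometry, with a stated time of 30 min; on this read-out higher numbers stand for weaker inhibition and lower numbers for stronger inhibition:
compound 1 `Cc1ccc(Nc2nnc(-c3ccccc3Cl)s2)cc1` gives 16700 nM
compound 2 `COc1ccc(-c2nnc(Nc3ccc(Cl)c(Cl)c3)s2)cc1` gives 4160 nM
compound 3 `Cc1ccc(-c2nnc(Nc3cccc(Br)c3)s2)c(C)c1` gives 36100 nM

Within this set compound 1 stands second highest of the three numbers. Its nearest neighbour is compound 3, whose number is higher and lies beyond the scatter; its furthest is compound 2, whose number is lower and also lies beyond the scatter. No two of the measured compounds differ in a single place, so none of these gaps can be tied to one structural change.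

Compound 4 `COc1ccccc1-c1nnc(Nc2ccc(C)cc2)s1` is not yet measured. It differs from compound 1 in one place: methoxy in place of chloro on an aromatic carbon. Among the measured compounds shown here, no measured pair isolates this exchange. Compound 2 also carries a methoxy and gives the lowest number of the three, but it differs from compound 1 in more than one place, so its value cannot be read as a step for the methoxy alone.

With nothing to anchor the direction, the expectation for compound 4 relative to compound 1 is a step of a 1.1-fold lower number from compound 1 to compound 4 (0.05 log units; within the scatter), not beyond the scatter. Compound 4 is estimated at 15000 nM, with a range from 5000 nM to 50000 nM.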

Compound 4, half-maximal inhibitory concentration: 58100 nM
Beside the measured number, compound 4's estimate is 3.9-fold (0.59 log units) below it; the measured number lies above the stated range.
By their numbers in this assay, from the lowest: compound 2; then compound 1; then compounds 3 and 4 (each within the scatter of the next).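

In this assay, methoxy in place of chloro on an aromatic carbon, ortho to a large group, gives a 3.5-fold higher number from compound 1 to compound 4 (0.54 log units; beyond the scatter) and so points towards weaker inhibition. Among the compounds shown here, this is the first step that isolates a single change, and it settles the direction for this exchange at this position on the core of compound 1: the exchange is not neutral, and chloro goes with the stronger inhibition of the pair. For the compounds shown here, the step shows only that the swap from one heavy atom with no hydrogen-bond acceptor to two heavy atoms with one acceptor goes with a higher number, and no measurement at hand accounts for it.

Still open, as far as these compounds go, is how far this holds for other groups at the same carbon, such as a hydroxyl, an amine, a carboxylic acid, bromo or a longer chain such as ethoxy, and whether the step depends on the methyl group that compound 1 and compound 4 share on their other aromatic ring. Whether the exchange runs the same way on a different aromatic carbon, or on a core carrying other substituents, also remains to be seen from a pair that differs in one place.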